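Swapping the Aryl Amide of Compound 3 for Propyl

The compounds below may be only part of what the source reports. "The series", "measured", "known", "first", "only" and "open" are said of these compounds alone.

Three compounds have been measured in a functional assay on U2OS cells (Homo sapiens) for antiproliferative activity, read by MTT assay, with a stated time of 72 h; on this read-out higher numbers stand for weaker inhibition and lower numbers for stronger inhibition:

Compound 1, `O=C(CSc1cccc(O)c1)Nc1ccc2nc(NC(=O)c3cc(Cl)cc(Cl)c3)sc2c1`, gives 1530 nM.
Compound 2, `O=C(CSc1ncc[nH]1)Nc1ccc2nc(NC(=O)c3ccc(C(F)(F)F)cc3)sc2c1`, gives 18800 nM.
Compound 3, `O=C(CSc1cccc(O)c1)Nc1ccc2nc(NC(=O)c3ccc(C(F)(F)F)cc3)sc2c1`, gives 630 nM.

Compound 3 stands at the lowest number of the three, and both gaps to it are beyond the scatter: the step from compound 1 was a 2.4-fold lower number from compound 1 to compound 3 (0.39 log units; beyond the scatter), and the step from compound 2 was a 30-fold lower number from compound 2 to compound 3 (1.47 log units; beyond the scatter). Compound 4, `CCCC(=O)Nc1nc2ccc(NC(=O)CSc3cccc(O)c3)cc2s1`, keeps the 3-hydroxyphenyl on the sulfur and changes the amide at the other end: propyl in place of 4-(trifluoromethyl)phenyl on a carbonyl carbon.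

Going by the values given here, only one measured step touches that carbonyl carbon, the modest 2.4-fold lower number from compound 1 to compound 3 (0.39 log units; beyond the scatter), and it exchanges one six-membered aromatic ring for another. Among the compounds with values here, no measured pair shows what happens when the ring is removed and a short chain takes its place, so the guide is weak. Losing an aromatic ring of that size in this position is expected to cost activity, so a step of a 4.8-fold higher number from compound 3 to compound 4 (0.68 log units; beyond the scatter) upward is expected, with wide uncertainty. Compound 4 is therefore estimated at 3000 nM, within 800 nM to 12000 nM.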

Compound 4, half-maximal inhibitory concentration: 10100 nM
For compound 4 the middle estimate is 3.4-fold (0.53 log units) below the measured one; the measured number falls inside the stated range.
By their numbers in this assay, from the lowest: compound 3; then compound 1; then compounds 4 and 2 (each within the scatter of the next).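

In this assay, the earlier step at this carbonyl carbon only exchanged one aromatic ring for another, and it was modest at a 2.4-fold lower number from compound 1 to compound 3 (0.39 log units; beyond the scatter); removing the ring altogether gives a large step, a 16-fold higher number from compound 3 to compound 4 (1.20 log units; beyond the scatter). The same exchange starting from the 3,5-dichlorophenyl group gives a 6.6-fold higher number from compound 1 to compound 4 (0.82 log units; beyond the scatter), so propyl raises the number from both aromatic starting points, meaning that activity falls in each case. Nothing available gives a measured reason for this loss.

Still open, going by these compounds, is whether the aromatic ring itself matters or simply the size of the group on the carbonyl carbon, a question that a cyclohexyl group or a longer chain such as hexyl could help settle. On these data alone, it is also open whether an amine on the ring would be tolerated, and whether propyl has a similar effect with 1H-imidazol-2-yl on the sulfur.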